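The compounds below may be only part of what the source reports. "The series", "measured", "known", "first", "only" and "open" are said of these compounds alone.

Of the compounds shown here, three share one urea core and have been measured in an ADME assay on the whole organism with Oryza sativa as the target, tested at 10 uM; a lower number here means a stronger effect, a higher number a weaker effect of the compound at the concentration tested. Compound 1, `CC(C)c1ccccc1NC(=O)N[C@@H](C)c1ccccc1`, gives 93%. Compound 3, `CCCc1ccc(NC(=O)N[C@@H](C)c2ccccc2)cc1`, gives 73%. Compound 2, `CCCc1ccc(NC(=O)N[C@H](C)c2ccccc2)cc1`, gives 35%, the lowest of the three numbers, with compound 3 as its nearest neighbour and compound 1 furthest away. Among the measured compounds shown here, the only measured step, a number 38 percentage points higher from compound 2 to compound 3 (beyond the scatter), rests on (the fact that compounds 2 and 3 differ only in the configuration as drawn). That step touches nothing but the drawn configuration at the saturated chain carbon, so it tells nothing about a longer chain on the aromatic ring.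

Compound 4, `CCCCCCc1ccc(NC(=O)N[C@H](C)c2ccccc2)cc1`, differs from compound 2 by propyl in place of hydrogen on a saturated chain carbon, three bonds along the chain from an aromatic carbon. For the measured compounds named here, no measured pair shows what such a longer chain does in this assay, so the expectation leans on compound 2 alone, anchored at 35% and given a wide margin. The expected change, a number 10 percentage points higher from compound 2 to compound 4 (within the scatter), is meant as no clear shift beyond the scatter. Compound 4 is therefore estimated at 45%, within a range from 15% to 85%.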

Compound 4, a percentage reported as activity, at one concentration (the size of the read-out at that concentration, not a potency): 101%
Compound 4: the middle estimate sits 56 percentage points below what was measured; the whole stated range lies below it.
By their numbers in this assay, from the lowest: compound 2; then compound 3; then compounds 1 and 4 (each within the scatter of the next).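

In this assay this chain position now has its first measured change: propyl in place of hydrogen, which turns the propyl chain of compound 2 into the hexyl chain of compound 4, gives a number 66 percentage points higher from compound 2 to compound 4 (beyond the scatter) and so a much weaker effect at the concentration tested. The earlier compounds shown here showed only that the drawn configuration can move this number, whereas this pair shows that the length of the chain on the aromatic ring can move it too. Nothing measured here accounts for the size of this step.

Going by these compounds, whether the number climbs gradually or abruptly between propyl and hexyl remains open, and a butyl or a pentyl chain would speak to that. Also open, on these data alone, are what a hexyl chain does with the opposite drawn configuration and what a hydroxyl or an amine at the chain end would do.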